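Stilbene-bearing picolinamides: an amide substituent swap

The compounds below may be only part of what the source reports. "The series", "measured", "known", "first", "only" and "open" are said of these compounds alone.

Compound 2, `COc1ccc(NC(=O)c2cc(Oc3ccc(/C=C/c4ccncc4)cc3)ccn2)cc1`, in a functional assay on A549 cells (Homo sapiens) for antiproliferative activity, read by CCK-8 assay, with a stated time of 48 h; a higher number here means a weaker inhibitor, a lower number a stronger inhibitor: 25600 nM
Compound 1, `O=C(Nc1ccccc1)c1cc(Oc2ccc(/C=C/c3ccncc3)cc2)ccn1`, in this assay: 79700 nM

Going by the values given here, compound 2 gives the lower of the two numbers measured so far in this assay; compound 1 sits a 3.1-fold lower number from compound 1 to compound 2 (0.49 log units; beyond the scatter) away from it, the sole measured step. Compound 3, `O=C(NCc1ccccc1)c1cc(Oc2ccc(/C=C/c3ccncc3)cc2)ccn1`, has not yet been measured. It differs from compound 2 by benzyl in place of 4-methoxyphenyl on an amide-type nitrogen. Among the compounds with values here, only the step from compound 1 to compound 2 bears on this change, and only in part: it shows that taking the methoxy away gives a modestly higher number, while nothing measured speaks to benzyl in place of phenyl on the amide-type nitrogen. Compound 3 is therefore expected to land a step of about a 2.3-fold higher number from compound 2 to compound 3 (0.37 log units; beyond the scatter) from compound 2, toward the level of compound 1, with wide uncertainty. The estimate for compound 3 in this assay is 60000 nM, expected to fall between 20000 nM and 180000 nM.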

Compound 3, half-maximal inhibitory concentration: 17000 nM
Compound 3: middle estimate off by 3.5-fold (0.55 log units), on the high side; measured number below the stated range.
By their numbers in this assay, from the lowest: compounds 3 and 2 (each within the scatter of the next); then compound 1.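

Benzyl in place of 4-methoxyphenyl on the amide-type nitrogen gives a 1.5-fold lower number from compound 2 to compound 3 (0.18 log units; within the scatter) in this assay, so these two groups cannot be told apart at this position. Benzyl in place of phenyl gives a 4.7-fold lower number from compound 1 to compound 3 (0.67 log units; beyond the scatter), which shows that methoxy on the phenyl ring is not the only change at this nitrogen that moves a compound beyond the scatter from compound 1. Nothing available explains either step.

Going by these compounds, it remains open whether 4-methoxybenzyl on the amide-type nitrogen would give a lower number than benzyl or 4-methoxyphenyl alone. On these data alone, the effect of a longer chain, such as 2-phenylethyl, or of a saturated ring, such as cyclohexyl, at the same nitrogen also remains open.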